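A few compounds are considered here, and "the series" means these few. Any claim that something is new, unique, unknown or untested is made for them only; others in the source may bear on it.

Of the compounds shown here, two with a shared core have been tested for how strongly they slow the growth of a human lymphoma cell line. In a functional assay on Raji cells (Homo sapiens) for antiproliferative activity, read by CCK-8 assay, with a stated time of 24 h (on this read-out lower numbers stand for stronger inhibition and higher numbers for weaker inhibition), compound 1 `C=CC(=O)Nc1cccc(Nc2ncnc(Nc3ccc(C(=O)Nc4ccccn4)cc3)n2)c1` gives 15600 nM. Compound 2 `C=CC(=O)Nc1cccc(Nc2ncnc(Nc3ccc(OC)cc3)n2)c1` gives 14500 nM. The two differ in a single place, a methoxy in place of a (pyridin-2-yl)carbamoyl on an aromatic carbon, and the change is a 1.1-fold lower number from compound 1 to compound 2 (0.03 log units; within the scatter). Compound 2 therefore holds the lowest of the two numbers, but its gap to compound 1 lies within the scatter, so the two cannot be told apart on these data.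

Compound 3 `C=CC(=O)Nc1cccc(Nc2ncnc(Nc3ccc(C(=O)Nc4ccc(C)cn4)cc3)n2)c1` has not yet been measured. It differs from compound 2 by (5-methylpyridin-2-yl)carbamoyl in place of methoxy on an aromatic carbon. Among the measured compounds shown here, this is nearly the reverse of the one measured step, with a methyl added on the entering ring. That step was within the scatter, so no shift beyond the scatter is expected in this assay. Compound 3 is expected to give about 15000 nM, with a likely range from 6000 nM to 40000 nM. The expected step is a 1.0-fold higher number from compound 2 to compound 3 (0.01 log units; within the scatter).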

Compound 3, half-maximal inhibitory concentration: 125000 nM
Beside the measured number, compound 3's estimate is 8.3-fold (0.92 log units) below it; the measured number lies above the stated range.
By their numbers in this assay, from the lowest: compounds 2 and 1 (each within the scatter of the next); then compound 3.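

The methyl is the feature that matters here: adding this one group to the pyridine ring of compound 1 gives an 8.0-fold higher number from compound 1 to compound 3 (0.90 log units; beyond the scatter) in this assay, so the antiproliferative effect weakens clearly with a very small change. The earlier pair suggested that this place on the aromatic ring, para to a large group, was indifferent to what sat there, since a 1.1-fold lower number from compound 1 to compound 2 (0.03 log units; within the scatter) showed that methoxy and (pyridin-2-yl)carbamoyl could not be told apart, whereas an 8.6-fold higher number from compound 2 to compound 3 (0.94 log units; beyond the scatter) shows that (5-methylpyridin-2-yl)carbamoyl does not share that neutrality. Nothing available here explains why the methyl has this effect.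

The compounds shown leave open whether the rise in the number is particular to methyl or would also follow from a chlorine, a fluorine or an ethyl group on the same pyridine ring. They also leave open whether a simple amine or a carboxylic acid in place of the methoxy of compound 2 would stay level with compound 2 or shift the number as far as the methyl did.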